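Swapping the benzyl substituent in a triazole-linked chromone series

The source may hold more compounds than are shown below. What is called first, only, known or untested is meant among the compounds shown, and "the series" means these compounds.

Measured so far:
- compound 1, `Cc1ccc(Cn2cc(COc3ccc4c(=O)ccoc4c3)nn2)cc1`: 10400 nM
- compound 2, `O=c1ccoc2cc(OCc3cn(Cc4ccc(Cl)cc4Cl)nn3)ccc12`: > 100000 nM
- compound 3, `CC(C)(C)c1ccc(Cn2cc(COc3ccc4c(=O)ccoc4c3)nn2)cc1`: 28800 nM

Of the compounds shown here, three sharing one core have been tested in a functional assay on SW480 cells (Homo sapiens) for cytotoxicity, read by MTT assay, with a stated time of 48 h; a higher number here means a weaker inhibitor, a lower number a stronger inhibitor. Compound 1 gives 10400 nM in this assay. With tert-butyl in place of methyl on an aromatic carbon, compound 3 gives 28800 nM, a change of a 2.8-fold higher number from compound 1 to compound 3 (0.44 log units; beyond the scatter). Compound 2 is different: in this assay it gives only a limit, > 100000 nM, so no number is known for it, and it sits at the limit of > 100000 nM in this assay, at which 1 of the 3 values shown sits. Relative to compound 1, the change of 2,4-dichlorophenyl in place of 4-methylphenyl on a saturated chain carbon bound to an aromatic nitrogen reads as an at least 9.6-fold higher number from compound 1 to compound 2 (0.98 log units; beyond the scatter).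

The next compound, compound 4, `N#Cc1cccc(Cn2cc(COc3ccc4c(=O)ccoc4c3)nn2)c1`, has not yet been measured. Against compound 2 the difference is 3-cyanophenyl in place of 2,4-dichlorophenyl on a saturated chain carbon bound to an aromatic nitrogen. Among the compounds with values here, no measured step covers a 3-cyanophenyl group, so the two steps seen so far only frame the possible range: one is modest, the other at least modest and heading toward weaker inhibition. Compound 4 is therefore expected to land around 35000 nM, within 8000 nM to 120000 nM. The implied step is estimated as an at least 2.8-fold lower number from compound 2 to compound 4 (0.45 log units; beyond the scatter), though with compound 2 known only as a limit this step is itself uncertain.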

Compound 4, half-maximal inhibitory concentration: > 100000 nM
Compound 4 gave a limit, no number (the forecaster's own chance of this, stated with the estimate: 35%); middle value at least 2.8-fold (0.45 log units) from the limit.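

In this assay compound 4 gives only a limit, not a number. Within the data shown here, the 3-cyanobenzyl group therefore joins 2,4-dichlorobenzyl as a second replacement on the saturated chain carbon bound to an aromatic nitrogen that gives no measurable value, while only compound 1 and compound 3 give numbers so far. The one readable step is an at least 9.6-fold higher number from compound 1 to compound 4 (0.98 log units; beyond the scatter), so replacing 4-methylphenyl with 3-cyanophenyl clearly weakens the result, although its full size is hidden; the step between the two limits cannot be read, and the series now presses against the top of what this assay can report: the limit of > 100000 nM in this assay, at which 2 of the 4 values shown sit.

The data leave open whether compound 2 and compound 4 differ at all, and whether the loss in compound 4 goes with the nitrile itself or with its place on the ring. A 4-cyanobenzyl group and a 3-methylbenzyl group would separate those two possibilities, since each changes only one of them relative to compound 4 or compound 1.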